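The compounds below may be only part of what the source reports. "The series", "measured", "known", "first", "only" and "open" are said of these compounds alone.

Measured so far in an ADME assay on Huh-7 cells (Homo sapiens) for cytotoxicity, with a stated time of 72 h; on this read-out lower numbers stand for higher toxicity in this test and higher numbers for lower toxicity in this test:
compound 1, `CCCN(C)c1nn(CCC(C)C)c(=O)c(C2=NS(=O)(=O)c3cc(NS(C)(=O)=O)ccc3N2)c1O`, gives > 1000 nM
compound 2, `CC(C)CCn1nc(N(C)C(C)C)c(O)c(C2=NS(=O)(=O)c3cc(NS(C)(=O)=O)ccc3N2)c1=O`, gives > 1000 nM
compound 3, `CC(C)CCn1nc(N2CCCC2)c(O)c(C2=Nc3ccc(NS(C)(=O)=O)cc3S(=O)(=O)N2)c1=O`, gives > 1000 nM

Each of these three entries is a limit of this assay and not a number. For compound 2 in particular only such a limit is known, so where compound 2 stands can be said only as far as the limit reaches; the two further values shown are limits as well (the limit of > 1000 nM in this assay, at which 3 of the 3 values shown sit). For the measured compounds named here, the one measured step at the site of interest, a step that the two limits leave unreadable from compound 1 to compound 2, is left unreadable by the two limits on either side of it and gives no size.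

Compound 4, `CC(C)CCn1nc(N2CCCCC2)c(O)c(C2=NS(=O)(=O)c3cc(NS(C)(=O)=O)ccc3N2)c1=O`, differs from compound 2 in one place: piperidin-1-yl in place of isopropyl(methyl)amino on an aromatic carbon. Going by the values given here, no measured step bears on this change with a readable size; compound 3, which also gives only a limit in this assay, adds nothing beyond that. With every value in the series sitting at the limit, no step beyond the scatter is expected from compound 2 to compound 4, so a step that the limit leaves unreadable from compound 2 to compound 4 is the estimated step. Compound 4 is therefore expected to give about 5000 nM in this assay, within 1000 nM to 30000 nM, most likely again reported only as a limit.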

Compound 4, half-maximal cytotoxic concentration: > 33000 nM
Compound 4 gave a limit, no number (the forecaster's own chance of this, stated with the estimate: 85%); middle value at least 6.6-fold (0.81 log units) away from the limit.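

In this assay, for the compounds shown here, compound 1, compound 2 and compound 4 all give limits and not numbers, and no step among them can be read. The compounds shown leave open at what concentration any of them becomes cytotoxic, and whether swapping the amino group changes that concentration.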